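Working notes: chloro to bromo exchange, compound 2 to compound 3

This account rests on a few compounds, and the source may have more. Where it says the series, first, only, none or still open, it means among the compounds named here.

Measured so far:
- compound 1 `Fc1cccc(-c2nc(Nc3ccccc3)c3cc(F)ccc3n2)c1`: in a functional assay on MDA-MB-231 cells (Homo sapiens) for cytotoxicity, read by MTT assay, with a stated time of 48 h (on this read-out higher numbers stand for weaker inhibition and lower numbers for stronger inhibition), compound 1 gives 47800 nM.
- compound 2 `Fc1cccc(-c2nc(Nc3ccccc3Cl)c3cc(F)ccc3n2)c1`: in this assay compound 2 gives only a limit, > 50000 nM.

Compound 2 stands at the ceiling of this assay; its reading is a limit and not a number, as noted in the limit of > 50000 nM in this assay, at which 1 of the 2 values shown sits. Within the data shown here, the one measured step that touches this part of the series is the change from hydrogen to chloro on the aromatic carbon, which read as an at least 1.0-fold higher number from compound 1 to compound 2 (0.01 log units; that floor lies within the scatter), a floor that lies within the scatter. Nothing in the two values separates compound 1 from compound 2 in this assay.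

Compound 3 `Fc1cccc(-c2nc(Nc3ccccc3Br)c3cc(F)ccc3n2)c1` carries the next halogen at the same place: bromo in place of chloro on an aromatic carbon. Among the measured compounds shown here, only the step from compound 1 to compound 2 bears on this change, and it was not beyond the scatter. Compound 3 is therefore expected to show no step beyond the scatter in this assay, that is a step that the limit leaves unreadable from compound 2 to compound 3, and a limit reading is the most probable outcome. For compound 3 the estimate in this assay is 60000 nM, with a range from 30000 nM to 150000 nM.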

Compound 3, half-maximal inhibitory concentration: > 50000 nM
Compound 3: a limit, no number (the forecaster's own chance of this, stated with the estimate: 65%); the middle value lies beyond the limit too.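

Chloro and bromo at this position now read the same way, as limits and not as numbers, in this assay: the limit of > 50000 nM in this assay, at which 2 of the 3 values shown sit.

Bromo in place of hydrogen gives an at least 1.0-fold higher number from compound 1 to compound 3 (0.01 log units; that floor lies within the scatter), so the second halogen, like chloro, shows no separation from compound 1 that can be read. The step between the two halogens cannot be read, so the series gives no ranking of chloro against bromo at this place.

As far as these compounds go, whether either halogen truly differs from compound 1 in this assay remains open, as the readings for compound 2 and compound 3 give no number to set against it. Also open, from the compounds shown here alone, is whether a methoxy, an amine or a carboxylic acid on the same aromatic carbon would give a reading that stands clear of the limit and of compound 1.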